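The source may hold more compounds than are shown below. What is called first, only, known or untested is meant among the compounds shown, and "the series" means these compounds.

In a functional assay on HCT-116 cells (Homo sapiens) for antiproliferative activity, read by MTT assay, with a stated time of 48 h (on this read-out lower numbers stand for stronger inhibition and higher numbers for weaker inhibition), compound 1 `CCCCCCC(CCO)n1cnc2c(OC)ncnc21` gives > 50000 nM, which is a limit and not a number. Compound 2 `CCCCCCC(CCO)n1cnc2c(N(C)C)ncnc21` gives > 50000 nM, also a limit. Compound 3 `CCCCCCC(CCO)n1cnc2c(N)ncnc21` gives > 50000 nM, again a limit. Compound 1 therefore stands at the limit of > 50000 nM in this assay, at which 3 of the 3 values shown sit. Compound 4 `CCCCCCCCCC(CCO)n1cnc2c(OC)ncnc21` differs from compound 1 in its chain: propyl in place of hydrogen on a saturated chain carbon, seven bonds along the chain from an aromatic nitrogen. The measured steps change only the group on the aromatic carbon, not the chain, and none has a readable size: a step that the two limits leave unreadable from compound 1 to compound 2, a step that the two limits leave unreadable from compound 1 to compound 3 and a step that the two limits leave unreadable from compound 2 to compound 3. They offer no firm guide, so only a modest shift toward stronger inhibition in this assay is expected, and the result may well remain a limit. The expected step is an at least 1.4-fold lower number from compound 1 to compound 4 (0.15 log units; that floor lies within the scatter). Compound 4 is estimated at 35000 nM, with an expected range from 10000 nM to 100000 nM.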

Compound 4, half-maximal inhibitory concentration: 2530 nM
Beside the measured number, compound 4's estimate is 14-fold (1.14 log units) above it; measured number below the stated range.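

In this assay the length of the chain proves able to move the read-out, which the changes on the aromatic carbon could not show: their steps cannot be read. Propyl in place of hydrogen at this chain carbon gives an at least 19-fold lower number from compound 1 to compound 4 (1.29 log units; beyond the scatter). Going by these compounds alone, compound 4 is the only compound here with a real number rather than a limit: the limit of > 50000 nM in this assay, at which 3 of the 4 values shown sit.

On these data alone, whether methyl, ethyl or a longer chain at this carbon would do the same stays open. So does whether amino or dimethylamino on the aromatic carbon would keep the gain with compound 4's chain.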